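Adding a Methoxy Group to Compound 3

The source may report more compounds than this note shows. Statements on the series, on what has been measured and on what is new or still open speak of the compounds shown alone.

- Compound 1 `Oc1nc(-c2ccccc2F)nc2ccccc12`: > 20 ug/mL (a limit)
- Compound 2 `COc1cc2nc(-c3ccc(F)cc3)nc(O)c2cc1OC`: > 20 ug/mL (a limit)
- Compound 3 `COc1cccc(-c2nc(O)c3cc(OC)ccc3n2)c1`: 1.98 ug/mL

All three compounds were tested in a functional assay on KB cells (Homo sapiens); on this read-out higher numbers stand for an effect only at larger amounts of compound and lower numbers for an effect already at smaller amounts. Compound 1 reports > 20 ug/mL, which is a limit and not a number. Compound 2 likewise reports > 20 ug/mL, also a limit. Compound 3, at 1.98 ug/mL, is the only one of the three with an actual number.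

Compound 4 `COc1cccc(-c2nc(O)c3cc(OC)c(OC)cc3n2)c1` has not yet been measured. It keeps compound 3 except for one change: methoxy in place of hydrogen on an aromatic carbon, ortho to a methoxy group (methoxy in place of hydrogen on an aromatic carbon). Among the measured compounds shown here, no measured pair shows this change on its own, so its size in this assay is uncertain. A modest shift toward needing larger amounts is expected, because of the limit of > 20 ug/mL in this assay, at which 2 of the 3 values shown sit. The expected step is a 2.0-fold higher number from compound 3 to compound 4 (0.31 log units; beyond the scatter), and it may not clear the usual scatter. For compound 4 the estimated value is 4 ug/mL, with an expected range of 1.2 ug/mL to 15 ug/mL.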

Compound 4, concentration for half-maximal effect: > 20 ug/mL
Compound 4 ended at the assay's limit; the forecaster's own chance of this, stated with the estimate: 25%; at least 5.0-fold (0.69 log units) between middle value and limit.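

In this assay, among the compounds shown here, the pair of compound 3 and compound 4 is the first to isolate a single change: methoxy in place of hydrogen on an aromatic carbon, ortho to a methoxy group. That one change gives an at least 10-fold higher number from compound 3 to compound 4 (1.00 log units; beyond the scatter), so this position does not tolerate the added methoxy without a clear loss on this read-out. The step gives only a minimum, because the reading of compound 4 is a limit and not a number: the limit of > 20 ug/mL in this assay, at which 3 of the 4 values shown sit.

The compounds shown leave open how far the true value of compound 4 lies past that limit. They also leave open whether the loss is specific to methoxy or would also follow from a smaller group on the same carbon, such as a fluorine atom, a hydroxyl or an amine.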